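Three hydrazones compared, a fourth awaiting its number

A few compounds are considered here, and "the series" means these few. Any claim that something is new, unique, unknown or untested is made for them only; others in the source may bear on it.

Three hydrazones built on the shared core were examined in an ADME assay on HEL cells (Homo sapiens) for cytotoxicity; a lower number here means that less compound is tolerated, a higher number that more compound is tolerated. Compound 1 `O=C(COc1cccc2ccccc12)N/N=C/c1cccc([N+](=O)[O-])c1` gives 61.2 ug/mL, compound 2 `Cc1ccc(/C=N/NC(=O)COc2cccc3ccccc23)cc1` gives 80.1 ug/mL, and compound 3 `C/C(=N\NC(=O)COc1cccc2ccccc12)c1ccc(O)cc1` gives 11.1 ug/mL. Compound 3 thus stands lowest of the three, with both other numbers beyond the scatter above it. Compound 4 `C/C(=N\NC(=O)COc1cccc2ccccc12)c1cccc([N+](=O)[O-])c1` differs from compound 3 in one place: 3-nitrophenyl in place of 4-hydroxyphenyl on a carbon with a double bond to nitrogen. Going by the values given here, no measured pair of compounds isolates this change, but compound 1 carries the same 3-nitrophenyl group and gives 61.2 ug/mL, so an upward step, beyond the scatter, is expected a 3.6-fold higher number from compound 3 to compound 4 (0.56 log units; beyond the scatter). In this assay compound 4 is therefore estimated at 40 ug/mL, with a range from 15 ug/mL to 100 ug/mL.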

Compound 4, half-maximal cytotoxic concentration: 10.5 ug/mL
For compound 4 the middle estimate is 3.8-fold (0.58 log units) above the measured one; measured number outside the range, below it.
By their numbers in this assay, from the lowest: compounds 4 and 3 (each within the scatter of the next); then compounds 1 and 2 (each within the scatter of the next).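

In this assay, 3-nitrophenyl in place of 4-hydroxyphenyl on a carbon with a double bond to nitrogen gives a 1.1-fold lower number from compound 3 to compound 4 (0.02 log units; within the scatter), so this change does not separate the two groups at this position. Carrying 3-nitrophenyl is thus not enough to give a number like that of compound 1, at 61.2 ug/mL, on this scaffold. Nothing available accounts for this result.

The compounds shown leave open whether any group at this position would separate from compound 3 and compound 4. As far as these compounds go, an amine or a carboxylic acid on the ring, for example, remains untested here.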